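Two Inactive Analogues and a Dimethylamino Swap

The compounds below may be only part of what the source reports. "The series", "measured", "known", "first", "only" and "open" are said of these compounds alone.

Compound 1 `COc1cc(C)cc(-c2c(-c3ccnc(-c4ccc(C(C)=O)cc4)c3)cnn2CC#N)c1` and compound 2 `Cc1cc(O)cc(-c2nn(CC#N)cc2-c2ccnc(-c3ccc(Oc4ccccc4)cc3)c2)c1` were both tested in a functional assay on HCC 2998 cells (Homo sapiens) for cytotoxicity, read by sulforhodamine B assay, with a stated time of 48 h, tested at 100 nM; a lower number here means a stronger effect, a higher number a weaker effect of the compound at the concentration tested. Compound 1 gave 104%, and compound 2 gave 107%. Among these two numbers compound 2 stands highest, but its nearest neighbour, compound 1, lies within the scatter of it, so the two cannot be told apart; both sit where no cytotoxic effect is seen at this concentration.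

Compound 3 `Cc1cc(O)cc(-c2nn(CC#N)cc2-c2ccnc(-c3ccc(N(C)C)cc3)c2)c1` has not yet been measured in this assay. It differs from compound 2 in one place: dimethylamino in place of phenoxy on an aromatic carbon.

For the measured compounds named here, no measured pair in this set shows what such a change does, so the expectation rests only on compound 2. Since compound 2 shows no effect at 107%, the step of a number 4 percentage points lower from compound 2 to compound 3 (within the scatter) is expected to be none beyond the scatter. Compound 3 is therefore estimated at 103%, within a range from 88% to 116%.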

Compound 3, a percentage reported as activity, at one concentration (the size of the read-out at that concentration, not a potency): 87%
For compound 3 the middle estimate is 16 percentage points above the measured one; measured number outside the range, below it.
By their numbers in this assay, from the lowest: compound 3; then compounds 1 and 2 (each within the scatter of the next).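

In this assay, for the compounds shown here, the place on an aromatic carbon, para to a large group, proves able to move the read-out: dimethylamino in place of phenoxy gives a number 20 percentage points lower from compound 2 to compound 3 (beyond the scatter) as a modest step, the first step in this set. The two groups match in their counts of hydrogen-bond donors and acceptors but differ in heavy atoms and in the ring that phenoxy carries, so in this single pair the lower number goes with a smaller group without a ring. No measurement available here accounts for the step.

This one pair cannot separate the loss of the ring from the arrival of the nitrogen. Going by these compounds, a primary amine, a diethylamino group or a morpholine ring at this place would bear on that, and how far the number can fall at this position remains open.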